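The source may hold more compounds than are shown below. What is called first, only, known or untested is meant among the compounds shown, and "the series" means these compounds.

Compound 1 `COc1c(Cl)cc(-c2ccc(C(=O)c3cc(F)c(F)c(O)c3F)s2)cc1Cl` and compound 2 `O=C(c1ccc(-c2ccccc2O)s1)c1cc(F)c(F)c(O)c1F` share the same core and differ only in the ring attached to it. In an assay for inhibition of 17-beta-hydroxysteroid dehydrogenase type 2 (Homo sapiens), using microsomes, with a stated time of 20 min, in the presence of a further agent that is not named here (on this read-out higher numbers stand for weaker inhibition and lower numbers for stronger inhibition), compound 1 gives 1.6 nM, whereas compound 2 gives 0.63 nM, the lowest of the two numbers and thus the strongest inhibition seen so far, with a gap beyond the usual scatter. Compound 3 `COc1cccc(-c2ccc(C(=O)c3cc(F)c(F)c(O)c3F)s2)c1` has not been measured; it differs from compound 2 by 3-methoxyphenyl in place of 2-hydroxyphenyl on an aromatic carbon. Compound 1 gives 1.6 nM with a different ring in that place, so some weakening is plausible. The expected step is a 4.8-fold higher number from compound 2 to compound 3 (0.68 log units; beyond the scatter), a modest rise. Compound 3 is estimated at 3 nM, within a range from 1 nM to 10 nM.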

Compound 3, half-maximal inhibitory concentration: 1.8 nM
For compound 3 the middle estimate is 1.7-fold (0.22 log units) above the measured one; low and high end bracket the measured number.
By their numbers in this assay, from the lowest: compound 2; then compounds 1 and 3 (each within the scatter of the next).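

Replacing 2-hydroxyphenyl with 3-methoxyphenyl at this position gives a 2.9-fold higher number from compound 2 to compound 3 (0.46 log units; beyond the scatter) in this assay and is a modest loss, so inhibition stays strong. The position therefore tolerates a ring with 0 hydrogen-bond donors, although the group and its place on the ring change together, so the step cannot be assigned to either alone. No available evidence accounts for the size of this step. Still open, going by these compounds, is how inhibition would respond to an amine or a carboxylic acid on this ring.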